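Triazole nitrogen substituent swap in the shared core

The source may report more compounds than this note shows. Statements on the series, on what has been measured and on what is new or still open speak of the compounds shown alone.

Of the compounds shown here, two have been measured in a functional assay on MCF7 cells (Homo sapiens) for inhibition, read by MTT assay, with a stated time of 24 h; a lower number here means a stronger inhibitor, a higher number a weaker inhibitor. Compound 1 `CCOC(=O)C1=Cc2ccccc2OC1(OCc1cn(CC(=O)Nc2ccc(C)cc2)nn1)C(F)(F)F` gives in this assay only a limit, > 150000 nM, which is the upper boundary of the measurement and not a number (the limit of > 150000 nM in this assay, at which 1 of the 2 values shown sits). Compound 2 `CCOC(=O)C1=Cc2ccccc2OC1(OCc1cc(-c2ccc3ccccc3c2)no1)C(F)(F)F` gives in this assay 65400 nM. Among the compounds with values here, no pair of measured compounds differs in a single place, so no measured step is available.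

Compound 3 `CCOC(=O)C1=Cc2ccccc2OC1(OCc1cn(-c2cccc(C(F)(F)F)c2)nn1)C(F)(F)F` is unmeasured. It differs from compound 1 by 3-(trifluoromethyl)phenyl in place of ((4-methylphenyl)carbamoyl)methyl on an aromatic nitrogen. Both measured compounds are weak in this assay, and the value of compound 1 is known only as a limit, so the size of the step toward compound 3 is uncertain; a move from the limit toward a measurable, somewhat stronger value is expected, though a repeat of the limit remains possible. Compound 3 is estimated at 80000 nM, with a range from 25000 nM to 250000 nM, an expected step of an at least 1.8-fold lower number from compound 1 to compound 3 (0.27 log units; that floor lies within the scatter).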

Compound 3, half-maximal inhibitory concentration: > 150000 nM
Compound 3: only a limit was reported (the forecaster's own chance of this, stated with the estimate: 40%); middle value at least 1.8-fold (0.27 log units) away from the limit.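

In this assay compound 3 gives > 150000 nM, a limit and not a number. Within the data shown here, compound 1 also stands at a limit, so no step between compound 1 and compound 3 can be read: the limit of > 150000 nM in this assay, at which 2 of the 3 values shown sit.

Which of 3-(trifluoromethyl)phenyl and ((4-methylphenyl)carbamoyl)methyl on the aromatic nitrogen gives the stronger inhibitor remains open.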